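Series notes: one replacement carried onto a second core

A few compounds are considered here, and "the series" means these few. Any claim that something is new, unique, unknown or untested is made for them only; others in the source may bear on it.

Compound 1 `O=c1cc(/C=N\c2ccc(O)cc2)c2ccc(OCc3ccccc3)cc2o1` is the reference point. In a functional assay, read by spectrophotometry, with a stated time of 1 h (a higher number here means a weaker inhibitor, a lower number a stronger inhibitor), compound 1 gives 233000 nM. Compound 3 `O=c1cc(/C=N\c2ccc(O)cc2)c2c(OCc3ccccc3)cc(OCc3ccccc3)cc2o1` differs from compound 1 by benzyloxy in place of hydrogen on an aromatic carbon. In this assay compound 3 gives 107000 nM, and the step of a 2.2-fold lower number from compound 1 to compound 3 (0.34 log units; beyond the scatter) is the only measured effect of that core difference. Compound 2 `O=c1cc(/C=N\Nc2ccc([N+](=O)[O-])cc2)c2ccc(OCc3ccccc3)cc2o1` differs from compound 1 by (4-nitrophenyl)amino in place of 4-hydroxyphenyl on a double-bonded nitrogen. In this assay compound 2 reaches only a limit of the assay, > 2000000 nM. The step of an at least 8.5-fold higher number from compound 1 to compound 2 (0.93 log units; beyond the scatter) is accordingly a lower bound, not a finished number.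

Compound 4 `O=c1cc(/C=N\Nc2ccc([N+](=O)[O-])cc2)c2c(OCc3ccccc3)cc(OCc3ccccc3)cc2o1` has not been measured. It relates to compound 3 exactly as compound 2 relates to compound 1: (4-nitrophenyl)amino in place of 4-hydroxyphenyl on a double-bonded nitrogen. The two place descriptions agree word for word, so this is the same change, made on the core of compound 3 instead of the core of compound 1; how those two cores differ is described above in the step from compound 1 to compound 3.

The expectation for compound 4 rests on compound 1 and compound 2, where the same change carried the value to the limit of > 2000000 nM in this assay, at which 1 of the 3 values shown sits, and on the starting point of compound 3 at 107000 nM, which is somewhat stronger than compound 1 by a 2.2-fold lower number from compound 1 to compound 3 (0.34 log units; beyond the scatter). Beside the measured at least 8.5-fold higher number from compound 1 to compound 2 (0.93 log units; beyond the scatter), the expected step is a 14-fold higher number from compound 3 to compound 4 (1.15 log units; beyond the scatter). Compound 4 is therefore estimated at 1500000 nM. For compound 4 the expected range runs from 400000 nM to 5000000 nM, with a real chance that this assay again reports only a limit.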

Compound 4, half-maximal inhibitory concentration: 97900 nM
The estimate for compound 4 lay 15-fold (1.19 log units) above the measured number, and the stated range ends above it.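

In this assay, the effect of (4-nitrophenyl)amino in place of 4-hydroxyphenyl on a double-bonded nitrogen did not carry from one core to the other: on the core of compound 3 the change gives a 1.1-fold lower number from compound 3 to compound 4 (0.04 log units; within the scatter), and this differs from the step on the core of compound 1: the same change on two cores in this assay, an at least 8.5-fold higher number (0.93 log units; beyond the scatter) from compound 1 to compound 2 and a 1.1-fold lower number (0.04 log units; within the scatter) from compound 3 to compound 4, at least 9.3-fold (0.97 log units) apart, beyond the scatter of two such steps

Read the other way, the effect of benzyloxy in place of hydrogen on an aromatic carbon depends on the group on the double-bonded nitrogen, with an at least 20-fold lower number from compound 2 to compound 4 (1.31 log units; beyond the scatter) set against the step between the compounds carrying 4-hydroxyphenyl: the same change on two cores in this assay, a 2.2-fold lower number (0.34 log units; beyond the scatter) from compound 1 to compound 3 and an at least 20-fold lower number (1.31 log units; beyond the scatter) from compound 2 to compound 4, at least 9.3-fold (0.97 log units) apart, beyond the scatter of two such steps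

Compound 2 gives only a limit of the assay, > 2000000 nM, which leaves the gap between the steps as a lower bound, and this single pair of cores gives neither a reason for the difference nor a rule for any other core.

The change replaces the ring substituent and the link to the ring together, so the compounds shown do not separate the nitro group from the amino link; a plain phenylamino group or a 4-hydroxyphenylamino group on the same nitrogen would bear on that. On these data alone, it also remains open whether the step on the core of compound 3 is specific to benzyloxy or would also appear with a smaller group such as methoxy in its place.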